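The source may hold more compounds than are shown below. What is called first, only, known or untested is meant among the compounds shown, and "the series" means these compounds.

Of the compounds shown here, two have been measured in an assay on isolated protein for inhibition of protein kinase C theta type (Homo sapiens), read by TR-FRET, with a stated time of 2 h; a lower number here means a stronger inhibitor, a higher number a weaker inhibitor. Compound 1 `N#Cc1cnc(NCc2cnccc2C(F)(F)F)cc1N[C@H]1CC[C@@H](O)CC1` gives 100 nM. Compound 2 `N#Cc1cnc(NCc2cnccc2C(F)(F)F)cc1N[C@H]1CC[C@H](O)CC1` gives 350 nM, the highest of the two numbers; its nearest neighbour is compound 1, and the step of a 3.5-fold higher number from compound 1 to compound 2 (0.54 log units; beyond the scatter) is modest but beyond the scatter. That step rests on nothing more than a change of configuration, as the fact that compounds 1 and 2 differ only in the configuration as drawn shows.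

Compound 3 `N#Cc1cnc(NCc2cnccc2C(F)(F)F)cc1NC[C@H]1CC[C@@H](O)CC1` has not yet been measured. It differs from compound 2 by (4-hydroxycyclohexyl)methyl in place of 4-hydroxycyclohexyl on a nitrogen on an aromatic ring. Among the measured compounds shown here, none of the measured steps bears directly on this change: the only step in hand, a 3.5-fold higher number from compound 1 to compound 2 (0.54 log units; beyond the scatter), concerns configuration alone, not a lengthening of the link between the ring nitrogen and the hydroxycyclohexyl group. The expected step of a 2.0-fold higher number from compound 2 to compound 3 (0.30 log units; within the scatter) is therefore taken with little confidence, and an outcome within the scatter cannot be ruled out. Compound 3 is expected to give 700 nM in this assay, with a range from 150 nM to 3500 nM.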

Compound 3, half-maximal inhibitory concentration: 58 nM
Estimate against measurement, compound 3: 12-fold (1.08 log units) above; the whole stated range lies above it.
By their numbers in this assay, from the lowest: compounds 3 and 1 (each within the scatter of the next); then compound 2.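

In this assay, the longer link costs nothing when read against compound 1: the step of a 1.7-fold lower number from compound 1 to compound 3 (0.24 log units; within the scatter) lies within the scatter, so (4-hydroxycyclohexyl)methyl stands in place of 4-hydroxycyclohexyl on this nitrogen on an aromatic ring without a loss that can be told from repeat measurement. Read against compound 2, the same exchange gives a 6.0-fold lower number from compound 2 to compound 3 (0.78 log units; beyond the scatter), a step beyond the scatter, so the size of the step depends on which of the two hydroxycyclohexyl compounds serves as the reference. The ring of compound 3 is drawn with the configuration as written for compound 1, and configuration alone already moves the number at this ring, so the larger step cannot be credited to the added methyl carbon by itself, as follows from this: the fact that compounds 1 and 2 differ only in the configuration as drawn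

The compounds shown leave open whether the ring of (4-hydroxycyclohexyl)methyl drawn in the other configuration would show a step like the one seen with the shorter link, so the weight of configuration on the longer link remains unknown. They also leave open how a longer chain such as an ethyl link would read at this nitrogen, and whether an amine or a carboxylic acid could stand in place of the hydroxyl on the ring.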